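Propyl in Place of Methyl on the Core of Compound 1

The source may hold more compounds than are shown below. What is called first, only, known or untested is meant among the compounds shown, and "the series" means these compounds.

Compound 1 `C[C@@]1(c2ccccc2)OCC[C@@H](CCN)O1` gives in an assay on brain for displacement of a labelled ligand from Sigma non-opioid intracellular receptor 1 (Cavia porcellus) (a lower number here means a stronger inhibitor, a higher number a weaker inhibitor), only a limit of the assay, > 10000 nM.
Compound 2 `C[C@]1(c2ccccc2)OCC[C@H](CCN)O1` gives in this assay only a limit of the assay, > 10000 nM.
Compound 3 `C[C@@]1(c2ccccc2)OCC[C@@H](CCNCc2ccccc2)O1` gives in this assay 17 nM.

Compound 1 stands at the weak end of what is shown: its value is a limit, not a number, and so is that of its mirror image, compound 2, so the step that the two limits leave unreadable from compound 1 to compound 2 cannot be read because the fact that compounds 1 and 2 differ only in the configuration as drawn and because of the limit of > 10000 nM in this assay, at which 2 of the 3 values shown sit. Among the measured compounds shown here, the only readable step is an at least 580-fold lower number from compound 1 to compound 3 (2.76 log units; beyond the scatter), which comes from putting benzyl on the amine nitrogen.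

Compound 4 `CCC[C@@]1(c2ccccc2)OCC[C@@H](CCN)O1` differs from compound 1 by ethyl in place of hydrogen on a saturated chain carbon bound to a saturated ring carbon. For the measured compounds named here, this change sits on a saturated chain carbon bound to a saturated ring carbon, and no measured step touches that place; the amine nitrogen, where the large step was seen, stays unchanged. The expectation is therefore a step that the limit leaves unreadable from compound 1 to compound 4, that is, none beyond the scatter, with compound 4 most likely again at a limit. Compound 4 is estimated at 15000 nM, within 3000 nM to 80000 nM.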

Compound 4, inhibition constant: > 10000 nM
Compound 4: no number, only a limit (the forecaster's own chance of this, stated with the estimate: 75%); the middle value is on the limit's open side.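

Compound 4, like compound 1, gives only a limit in this assay, so no step between the two can be read: the limit of > 10000 nM in this assay, at which 3 of the 4 values shown sit.

The compounds shown leave open whether propyl in place of methyl changes the result when benzyl sits on the amine nitrogen, as in compound 3.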